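The source may report more compounds than this note shows. Statements on the series, on what has been measured and on what is new or still open speak of the compounds shown alone.

Compound 1 `C#C[C@H](CC(=O)O)NC(=O)CCC(=O)Nc1ccc(C(=N)N)cc1` gives 6.5 h in an in vivo ADME assay on the whole organism for pharmacokinetics, with Canis familiaris (Canis lupus familiaris) as the target, at a dose of 2.5 mg/kg by the intravenous route; on this read-out lower numbers stand for a shorter-lived compound and higher numbers for a longer-lived compound. Compound 2 `C#C[C@H](CC(=O)OCC)NC(=O)CCC(=O)Nc1ccc(C(=N)N)cc1` carries ethyl in place of hydrogen on an oxygen next to a carbonyl group and gives 1.6 h in this assay, so that a 4.1-fold lower number from compound 1 to compound 2 (0.61 log units; beyond the scatter). Compound 3 `N=C(N)c1ccc(NC(=O)CCC(=O)N[C@@H](CC(=O)O)c2cccnc2)cc1` gives 5.6 h in this assay; its core differs from the core of compound 1 by pyridin-3-yl in place of ethynyl on a saturated chain carbon bound to an amide-type nitrogen and a saturated chain carbon, and a 1.2-fold lower number from compound 1 to compound 3 (0.06 log units; within the scatter). Compound 4 `CCOC(=O)C[C@H](NC(=O)CCC(=O)Nc1ccc(C(=N)N)cc1)c1cccnc1` has not yet been measured in this assay. Within the data shown here, it differs from compound 3 by ethyl in place of hydrogen on an oxygen next to a carbonyl group, the same change at the same place as the one between compound 1 and compound 2. The step in this assay is expected to be a 4.0-fold lower number from compound 3 to compound 4 (0.60 log units; beyond the scatter), set beside the earlier one, because the same change gave a 4.1-fold lower number from compound 1 to compound 2 (0.61 log units; beyond the scatter). For compound 4 the estimated value is 1.4 h, with a likely range from 0.7 h to 2.8 h.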

Compound 4, half-life: 0.5 h
Compound 4: middle estimate off by 2.8-fold (0.45 log units), on the high side; the whole stated range lies above it.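

In this assay, the change from carboxy to ethoxycarbonyl shortens the half-life on both cores, here with an 11-fold lower number from compound 3 to compound 4 (1.05 log units; beyond the scatter), but its size does not carry over unchanged: the same change on two cores in this assay, a 4.1-fold lower number (0.61 log units; beyond the scatter) from compound 1 to compound 2 and an 11-fold lower number (1.05 log units; beyond the scatter) from compound 3 to compound 4, 2.8-fold (0.44 log units) apart, beyond the scatter of two such steps. Likewise, pyridin-3-yl in place of ethynyl gives a step within the scatter on the carboxy compounds, yet a 3.2-fold lower number from compound 2 to compound 4 (0.51 log units; beyond the scatter) on the ethoxycarbonyl compounds: the same change on two cores in this assay, a 1.2-fold lower number (0.06 log units; within the scatter) from compound 1 to compound 3 and a 3.2-fold lower number (0.51 log units; beyond the scatter) from compound 2 to compound 4, 2.8-fold (0.44 log units) apart, beyond the scatter of two such steps. The two changes therefore do not simply add up in these four compounds, although this rests on a single pair of cores and does not show why the steps differ.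

From the compounds shown here alone, whether a methyl ester, a longer chain on the oxygen or an amide in place of the carboxy group would follow either step remains open. So does whether a different ring in place of pyridin-3-yl would widen the ester step.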